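A few compounds are considered here, and "the series" means these few. Any claim that something is new, unique, unknown or untested is made for them only; others in the source may bear on it.

Within the data shown here, in a functional assay on PC-3 cells (Homo sapiens) for inhibition, read by sulforhodamine B assay (on this read-out lower numbers stand for stronger inhibition of growth and higher numbers for weaker inhibition of growth), only two compounds built on the shared core have been read so far. Compound 1 `COc1cccc(CN2CCC=C(CCC(=O)NO)C2=O)c1` gives > 10000 nM, which is a limit of the assay and not a number. Among the measured compounds shown here, compound 2 `Cc1ccc(CN2CCC=C(CCC(=O)NO)C2=O)cc1` gives 8100 nM, so it holds the only true number available and has no measured neighbour to be ranked against. Compound 3 `Cc1cccc(CN2CCC=C(CCC(=O)NO)C2=O)c1` has the same atoms as compound 2, joined differently: 3-methylphenyl in place of 4-methylphenyl on a saturated chain carbon bound to an amide-type nitrogen in a ring. For the measured compounds named here, no measured step covers this change. With compound 2 at 8100 nM as the sole anchor, the expected shift in this assay is small, with no change beyond the scatter and only a slight lean toward weaker inhibition of growth. The estimated step of a 1.1-fold higher number from compound 2 to compound 3 (0.05 log units; within the scatter) stays within that scatter. For compound 3 the estimated value is 9000 nM, with an expected range of 4500 nM to 16000 nM.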

Compound 3, concentration for 50% growth inhibition: > 10000 nM
Compound 3 ended at the assay's limit (the forecaster's own chance of this, stated with the estimate: 40%); at least 1.1-fold (0.04 log units) between middle value and limit.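

Among these compounds, the change from 4-methylphenyl in compound 2 to 3-methylphenyl in compound 3, on a saturated chain carbon bound to an amide-type nitrogen in a ring, now has a first measured step in this assay: an at least 1.2-fold higher number from compound 2 to compound 3 (0.09 log units; that floor lies within the scatter). In this step compound 3 gives > 10000 nM, which is a limit of the assay and not a number, so only a floor for the step can be stated. The step from compound 1 to compound 3, methyl in place of methoxy on an aromatic carbon, cannot be read, because both values are limits: the limit of > 10000 nM in this assay, at which 2 of the 3 values shown sit.

As far as these compounds go, whether moving the methyl changes growth inhibition beyond the scatter remains open. Also open, from the compounds shown here alone, is how an amine or a carboxylic acid in place of that methyl would read in this assay.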